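Meta-chloro on the phenyl of compound 1

This account rests on a few compounds, and the source may have more. Where it says the series, first, only, none or still open, it means among the compounds named here.

Measured so far:
- compound 1, `Cn1c(-c2ccccc2)nc2c(NC3CCCC3)ncnc21`: 2.8 nM
- compound 2, `CCn1c(-c2ccccc2)nc2c(NC3CCC3)ncnc21`: 6 nM

In an assay on CHO cells for displacement of a labelled ligand from adenosine receptor A1 (Homo sapiens), read by scintillation counting, with a stated time of 3 h (a lower number here means a stronger inhibitor, a higher number a weaker inhibitor), compound 1 gives 2.8 nM, the lower of the two numbers in hand. Compound 2 gives 6 nM, a higher number that lies beyond the usual scatter, so compound 1 is the stronger inhibitor of the pair. Compound 2 differs from compound 1 in more than one place, so its gap to compound 1 is not traced to a single change.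

The next compound is compound 3, `Cn1c(-c2cccc(Cl)c2)nc2c(NC3CCCC3)ncnc21`. It differs from compound 1 by one change: chloro in place of hydrogen on an aromatic carbon. Within the data shown here, no measured pair in this set carries the same change, so there is no step to lean on. A single chloro entering on an aromatic carbon of the phenyl is a small addition, and in this assay it is expected to move the number little, in either direction, most likely within the scatter; a modest gain is as plausible as a modest loss. The step from compound 1 to compound 3 is therefore estimated as a 1.1-fold lower number from compound 1 to compound 3 (0.05 log units; within the scatter). For compound 3 the expected value is 2.5 nM, with a range of 1 nM to 7 nM.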

Compound 3, inhibition constant: 6.5 nM
The estimate for compound 3 lay 2.6-fold (0.41 log units) below the measured number; the measured number falls inside the stated range.
By their numbers in this assay, from the lowest: compound 1; then compounds 2 and 3 (each within the scatter of the next).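

Among these compounds, the phenyl is the first place where a single change can be read: in this assay, phenyl to 3-chlorophenyl gives a 2.3-fold higher number from compound 1 to compound 3 (0.37 log units; beyond the scatter), a modest step. This position, meta to a large group, therefore takes chloro in place of hydrogen with a measurable change towards a weaker inhibitor, although compound 3 at 6.5 nM keeps much of the strength of compound 1. Nothing at hand bears on the reason for this step.

On these data alone, with one step at one position, it stays open whether the rise is specific to chloro or would also follow from another group on the same carbon, such as fluoro, methyl, methoxy or an amine. Compound 2 differs from compound 1 in more than one place, so its separate changes also stay unresolved, and the effect of chloro on the phenyl is known only with the substituents of compound 1 in place.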